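Swapping trifluoromethyl for oxan-4-yl on the shared core

The source may hold more compounds than are shown below. What is called first, only, known or untested is meant among the compounds shown, and "the series" means these compounds.

For the measured compounds named here, compound 2 `C[C@@H]1CC(=O)Nc2ncnc(N3CCC(c4nc(C(F)(F)F)cn4CCN4CCCC4)CC3)c21` carries the highest number of the two measured so far in an assay on isolated protein for inhibition of ribosomal protein S6 kinase alpha-1 (Homo sapiens); a higher number here means a weaker inhibitor, a lower number a stronger inhibitor: compound 2 gives 272 nM. Going by the values given here, its nearest neighbour, compound 1 `C[C@@H]1CC(=O)Nc2ncnc(N3CCC(c4nc(-c5ccc(F)c(C(F)(F)F)c5)cn4CCN4CCCC4)CC3)c21`, gives 20 nM in this assay, and the step of a 14-fold higher number from compound 1 to compound 2 (1.13 log units; beyond the scatter) is the only measured step, made at the same aromatic carbon that is altered again now. Compound 3 `C[C@@H]1CC(=O)Nc2ncnc(N3CCC(c4nc(C5CCOCC5)cn4CCN4CCCC4)CC3)c21` differs from compound 2 by oxan-4-yl in place of trifluoromethyl on an aromatic carbon. That single step is the only one bearing on the new change, and it shows that the number at this position can move a long way when the group is exchanged. Oxan-4-yl is neither the trifluoromethyl of compound 2 nor the aryl of compound 1, so a moderate downward move is expected, as a 2.3-fold lower number from compound 2 to compound 3 (0.36 log units; beyond the scatter). Compound 3 is therefore estimated at 120 nM in this assay, between 40 nM and 400 nM.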

Compound 3, half-maximal inhibitory concentration: 699 nM
Compound 3: the middle estimate sits 5.8-fold (0.77 log units) below what was measured; measured number above the stated range.
By their numbers in this assay, from the lowest: compound 1; then compound 2; then compound 3.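

In this assay the new group does not bring the number down toward that of the aryl compound: oxan-4-yl gives a 2.6-fold higher number from compound 2 to compound 3 (0.41 log units; beyond the scatter) and so ranks behind even the small trifluoromethyl at this aromatic carbon. Set against the aryl group directly, the same ring gives a 35-fold higher number from compound 1 to compound 3 (1.54 log units; beyond the scatter) and this makes compound 3 the weakest of the three, so a larger group with a ring at this position does not by itself give a lower number. No supporting measurement is available to explain this order of the three groups.

As far as these compounds go, whether the low number of compound 1 needs an aromatic ring or its fluorine and trifluoromethyl substituents remains open. An unsubstituted phenyl would separate those two readings, and a piperidin-4-yl, with an amine nitrogen in place of the ring oxygen, would test that oxygen.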